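Adding a fluoro to the best chlorophenyl sulfone

The source may report more compounds than this note shows. Statements on the series, on what has been measured and on what is new or still open speak of the compounds shown alone.

Three esters that share one core have been measured in a functional assay on RAW264.7 cells (Mus musculus), read by fluorescence; on this read-out higher numbers stand for weaker inhibition and lower numbers for stronger inhibition. Compound 1 `CCOC(=O)C1=CCCCC1S(=O)(=O)Cc1ccccc1F` gives 97 nM, compound 2 `CCOC(=O)C1=CCCCC1S(=O)(=O)Cc1cccc(Cl)c1` gives 14 nM, and compound 3 `CCOC(=O)C1=CCCCC1S(=O)(=O)Cc1ccc(Cl)cc1` gives 101 nM. Compound 2 therefore stands at the lowest number of the three: the step of a 6.9-fold lower number from compound 1 to compound 2 (0.84 log units; beyond the scatter) and the step of a 7.2-fold higher number from compound 2 to compound 3 (0.86 log units; beyond the scatter) both lie beyond the scatter, whereas the step of a 1.0-fold higher number from compound 1 to compound 3 (0.02 log units; within the scatter) lies within it.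

Compound 4 `CCOC(=O)C1=CCCCC1S(=O)(=O)Cc1cc(Cl)ccc1F` differs from compound 2 by fluoro in place of hydrogen on an aromatic carbon. For the measured compounds named here, no measured step adds a second halogen to a ring that already carries one; each measured step exchanges one halogenated ring for another. The nearest guidance is that compound 1, carrying a fluoro alone, and compound 3, carrying a chloro alone, give numbers close to each other, and that the chloro arrangement of compound 2 is what brought the number down. Compound 4 keeps that chloro and merely adds a fluoro, so the step of a 1.4-fold higher number from compound 2 to compound 4 (0.15 log units; within the scatter) is expected to be small and to fall within the scatter, with a slight lean toward a higher number. Compound 4 is expected to give about 20 nM, with a range from 7 nM to 60 nM.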

Compound 4, half-maximal inhibitory concentration: 23 nM
Compound 4: the middle estimate sits 1.2-fold (0.06 log units) below what was measured; the range from low to high includes it.
By their numbers in this assay, from the lowest: compounds 2 and 4 (each within the scatter of the next); then compounds 1 and 3 (each within the scatter of the next).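

In this assay, the aromatic carbon ortho to a large group and para to a chloro group accepts a fluoro on the ring of compound 2, with a 1.6-fold higher number from compound 2 to compound 4 (0.22 log units; within the scatter) as the whole of the change, so this position can carry the new halogen while the number stays within the scatter. Read from the other side, chloro in place of hydrogen gives a 4.2-fold lower number from compound 1 to compound 4 (0.63 log units; beyond the scatter) on a ring that already carries a fluoro, which shows for the first time that adding a second halogen can move the number beyond the scatter, and that of the two additions to compound 4 only the chloro does so. Nothing available here bears on why either step has the size it has.

From the compounds shown here alone, it remains open whether the same aromatic carbon would accept methoxy, methyl or trifluoromethyl as it accepts fluoro, or whether a hydroxyl there would leave the number within the scatter as well. Going by these compounds, it is also open whether the ethyl ester of the shared core could give way to a carboxylic acid or an amide while the halogens of compound 4 stay in place.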